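The source may hold more compounds than are shown below. What is called first, only, known or untested is meant among the compounds shown, and "the series" means these compounds.

Measured so far in a functional assay on thoracic aorta for antagonist activity at Alpha-1D adrenergic receptor (Rattus norvegicus); a higher number here means a more potent compound, by a factor of ten per unit of this negative logarithm, a lower number a less potent compound:
compound 1 `COc1cccc(OC)c1OCCNCCOc1ccccc1OCc1ccc(Cl)cc1` — 9.11
compound 2 `COc1cccc(OC)c1OCCNCCOc1ccccc1OCc1ccccc1C` — 8.64
compound 3 `COc1ccccc1COc1ccccc1OCCNCCOc1c(OC)cccc1OC` — 8.86

Compound 3 stands second of the three, with compound 2 nearest and compound 1 furthest, both separations within the scatter. Compound 4 is `COc1ccc(COc2ccccc2OCCNCCOc2c(OC)cccc2OC)cc1`; the change is 4-methoxyphenyl in place of 2-methoxyphenyl on a saturated chain carbon bound to an oxygen on an aromatic ring. Going by the values given here, the steps that bear on this position are a number 0.25 log units lower from compound 1 to compound 3 (within the scatter) and a number 0.47 log units lower from compound 1 to compound 2 (beyond the scatter); the step of a number 0.22 log units higher from compound 2 to compound 3 (within the scatter) shows that exchanging the group on the aromatic carbon at this position moves little. The three measured variants at this position span a narrow band, so for compound 4 a step of a number 0.14 log units higher from compound 3 to compound 4 (within the scatter) is expected, within the scatter. Compound 4 is estimated at 9 in this assay, with a range of 8.5 to 9.4.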

Compound 4, negative logarithm of the antagonist equilibrium constant: 9.21
Estimate against measurement, compound 4: 0.21 log units below; the range from low to high includes it.
By their numbers in this assay, from the lowest: compounds 2, 3, 1 and 4 (each within the scatter of the next, the first and the last beyond it).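

In this assay, the same methoxy on the same phenyl gives a measurable shift with its place alone, a number 0.35 log units higher from compound 3 to compound 4 (beyond the scatter), and 4-methoxyphenyl also clears 2-methylphenyl, a number 0.57 log units higher from compound 2 to compound 4 (beyond the scatter). 4-Methoxyphenyl and 4-chlorophenyl are not told apart, a number 0.10 log units higher from compound 1 to compound 4 (within the scatter), so the methoxy and chloro exchange at that place moves little. No supporting data explain the shift.

Going by these compounds alone, open is whether the shift holds for other groups on the phenyl, as only one pair of methoxy placements is at hand. An amine or a carboxylic acid in place of that methoxy would test how much the group itself counts.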